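Removing a Methoxy Group: From Compound 1 to Compound 3

A few compounds are considered here, and "the series" means these few. Any claim that something is new, unique, unknown or untested is made for them only; others in the source may bear on it.

Of the compounds shown here, two sharing one core have been tested in a functional assay on the whole organism (strain albino) for inhibition, with Rattus norvegicus as the target, read by paw edema, with a stated time of 30 min, at a dose of 100 mg/kg by the oral route; on this read-out higher numbers stand for more inhibition at the one dose given (going by the name of the read-out) and lower numbers for less inhibition. Compound 1 `COc1ccc(NCc2nc3ccccc3[nH]2)cc1` gives 7.6%, the lowest of the two numbers. Compound 2 `Clc1cccc(NCc2nc3ccccc3[nH]2)c1` gives 15.3%, which lies within the usual scatter of the result for compound 1, so the two cannot be told apart. Compound 3 `c1ccc(NCc2nc3ccccc3[nH]2)cc1` is not yet measured; it differs from compound 1 in one place: hydrogen in place of methoxy on an aromatic carbon. For the measured compounds named here, no step between measured compounds is known, so nothing measured guides this change, and a step no larger than the scatter is expected, in either direction. Compound 3 is expected to give about 10%, within 0% to 25%, an expected step of a number 2.4 percentage points higher from compound 1 to compound 3 (within the scatter).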

Compound 3, a percentage reported as inhibition, in the whole organism at one dose (the size of the read-out at that dose, not a potency): 7.6%
Estimate against measurement, compound 3: 2.4 percentage points above; the measured number falls inside the stated range.
By their numbers in this assay, from the lowest: compounds 1, 3 and 2 (each within the scatter of the next).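

In this assay, the unsubstituted ring can now be compared directly with a substituted one: hydrogen in place of methoxy gives no change at the digits printed from compound 1 to compound 3 (within the scatter), so at this one dose the methoxy group on this aromatic carbon is not shown to matter. Hydrogen in place of chloro gives a number 7.7 percentage points lower from compound 2 to compound 3 (within the scatter), so that group is not shown to matter either. No measurement available here explains these results. Still open, on these data alone, is whether an amine or a carboxylic acid on this aromatic carbon would give a number that stands apart from that of compound 3.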